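Swapping the carbamoyl of compound 3 for a carboxy group

The compounds below may be only part of what the source reports. "The series", "measured", "known", "first", "only" and "open" are said of these compounds alone.

Compound 3 `CC(C)C[C@@H]1NC(=O)[C@H](CC(N)=O)NC1=O` gives 0% in a functional assay, tested at 2.5 mM (a higher number here means more inhibition at the concentration tested (going by the name of the read-out), a lower number less inhibition), level with compound 2 `CC(C)C[C@@H]1NC(=O)[C@H](CCC(=O)O)NC1=O`, which gives 0%, the two together the lowest of the three numbers, and far from compound 1 `CC(C)C[C@@H]1NC(=O)[C@H](CS)NC1=O`, which gives 83.3%. Compound 4 `CC(C)C[C@@H]1NC(=O)[C@H](CC(=O)O)NC1=O` differs from compound 3 by hydroxy in place of amino on a carbonyl carbon, that is carbamoyl to carboxy. Among the measured compounds shown here, two measured steps bear on this change: no change at the digits printed from compound 2 to compound 3 (within the scatter), and a number 83.3 percentage points lower from compound 1 to compound 3 (beyond the scatter). Only the sulfanyl compound inhibits in this assay, while carboxymethyl and carbamoyl both sit at the bottom, and a carboxy group is expected to behave like those two. Compound 4 is expected to show a number 2 percentage points higher from compound 3 to compound 4 (within the scatter). The estimate for compound 4 is 2%, with a range from 0% to 12%.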

Compound 4, a percentage reported as inhibition, at one concentration (the size of the read-out at that concentration, not a potency): 0%
The estimate for compound 4 lay 2 percentage points above the measured number; low and high end bracket the measured number.
By their numbers in this assay, from the lowest: compounds 2, 3 and 4 (each within the scatter of the next); then compound 1.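

In this assay, hydroxy in place of amino on a carbonyl carbon gives no change at the digits printed from compound 3 to compound 4 (within the scatter), and carboxy in place of carboxymethyl gives no change at the digits printed from compound 2 to compound 4 (within the scatter), so carbamoyl, carboxymethyl and carboxy cannot be told apart here. Carboxy in place of sulfanyl gives a number 83.3 percentage points lower from compound 1 to compound 4 (beyond the scatter), so sulfanyl remains the only one of the four groups shown that goes with inhibition. Nothing given here explains this.

On these data alone, it remains open whether a hydroxy group or an amine in place of sulfanyl on that chain carbon would inhibit, and whether the inhibition of compound 1 requires sulfanyl itself.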